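The compounds below may be only part of what the source reports. "The series", "measured", "known", "first", "only" and "open" are said of these compounds alone.

Measured compounds:
compound 1, `O=C1C(Cc2n[nH]c3ccccc23)C(=O)N(c2ccccc2)C=CN1CC(=O)N1CCCCc2ccccc21` — 1.59 nM
compound 2, `COc1ccc(N(C(=O)CN2C=CN(C3CCCCC3)C(=O)C(Cc3n[nH]c4ccccc34)C2=O)C(C)C)cc1` — 31600 nM; > 30000 nM (2 entries)
compound 3, `COc1ccc(N(C(=O)CN2C=CN(c3ccccc3)C(=O)C(Cc3nn(C)c4ccccc34)C2=O)C(C)C)cc1` — 31600 nM; > 30000 nM (2 entries)

Going by the values given here, in a functional assay on CHO cells for agonist activity at Melanocyte-stimulating hormone receptor (Homo sapiens), read by a luciferase reporter, with a stated time of 4 h (a lower number here means that less compound is needed, a higher number that more compound is needed for the effect), compound 1 gives 1.59 nM, the only single number; two further entries for it come without a number. Compound 2 gives 31600 nM; > 30000 nM (2 entries). Compound 3 gives 31600 nM; > 30000 nM (2 entries). The repeated entries for compound 2 are summarised as the several entries of compound 2 in this assay, 31600 nM; > 30000 nM (2 entries) and those for compound 3 as the several entries of compound 3 in this assay, 31600 nM; > 30000 nM (2 entries).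

Compound 4, `COc1ccc(N(C(=O)CN2C=CN(c3ccccc3)C(=O)C(Cc3n[nH]c4ccccc34)C2=O)C(C)C)cc1`, is not yet measured in this assay. It keeps the core of compound 1 and differs from it by a group of 12 heavy atoms (10 carbon, 1 nitrogen, 1 oxygen; one six-membered aromatic ring of carbon only) in place of a group of 11 heavy atoms (10 carbon, 1 nitrogen; one six-membered aromatic ring of carbon only, one seven-membered non-aromatic ring with 1 hetero atom), on a carbonyl carbon.

Among the compounds with values here, no step between measured compounds is available, so the size of the change from compound 1 to compound 4 in this assay has to be estimated. Compounds 2 and 3 each differ from compound 4 in a further place and do not settle the amide change on its own. A loss beyond the scatter is expected, of moderate size, with compound 4 still giving a number rather than a limit. Compound 4 is expected at 12 nM, within 1.5 nM to 300 nM, an estimated step of a 7.5-fold higher number from compound 1 to compound 4 (0.88 log units; beyond the scatter).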

Compound 4, half-maximal effective concentration: 29.5 nM
Compound 4: the middle estimate sits 2.5-fold (0.39 log units) below what was measured; measured number inside the range.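

In this assay, the isopropyl(4-methoxyphenyl)amino group on the carbonyl carbon, in place of the group with the seven-membered non-aromatic ring, gives a 19-fold higher number from compound 1 to compound 4 (1.27 log units; beyond the scatter), a large loss, yet compound 4 still returns a number, so that ring is not required for a measured value at this place. Compound 2 carries the same isopropyl(4-methoxyphenyl)amino group and differs from compound 4 in one further place, so this group alone does not account for its entries, which include a limit of the assay: the several entries of compound 2 in this assay, 31600 nM; > 30000 nM (2 entries). Compound 3 also carries this group and differs from compound 4 in a different further place, so the same holds for its entries, which also include a limit of the assay: the several entries of compound 3 in this assay, 31600 nM; > 30000 nM (2 entries).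

The sizes of the steps from compound 4 to compound 2 and to compound 3 cannot be read. On these data alone, with a single change on the carbonyl carbon, it remains open whether the isopropyl or the 4-methoxyphenyl part sets the loss, and a smaller amine such as dimethylamino or a morpholine amide in this place would test how much of either is needed.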